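A few compounds are considered here, and "the series" means these few. Any claim that something is new, unique, unknown or untested is made for them only; others in the source may bear on it.

Compound 1 `C=CCc1cc(C(C)=O)c(O)cc1OCCCCC#N` gives 92% in an assay on isolated protein for inhibition of leukotriene B4 receptor 1 (Homo sapiens), tested at 10 uM; a higher number here means more inhibition at the concentration tested (going by the name of the read-out), a lower number less inhibition. Compound 2 `C=CCc1ccc(O)cc1OCCCCC#N` gives 29% in this assay, the step being a number 63 percentage points lower from compound 1 to compound 2 (beyond the scatter). Compound 3 `C=CCc1cc(C(=O)CC)c(O)cc1OCCCCC#N` gives 77% in this assay, which places it second of the three numbers shown: a number 15 percentage points lower from compound 1 to compound 3 (beyond the scatter), and a number 48 percentage points higher from compound 2 to compound 3 (beyond the scatter).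

Compound 4 `C=CCc1cc(C(=O)CCCCCCCCC)c(O)cc1OCCCCC#N` differs from compound 3 by heptyl in place of hydrogen on a saturated chain carbon, two bonds along the chain from a carbonyl carbon. Of the measured steps, the one that bears most directly on this change is the only one that alters the chain beyond the carbonyl, reading a number 15 percentage points lower from compound 1 to compound 3 (beyond the scatter), a modest lowering. The two large steps, a number 63 percentage points lower from compound 1 to compound 2 (beyond the scatter) and a number 48 percentage points higher from compound 2 to compound 3 (beyond the scatter), concern the presence of the acyl group itself and give less direct guidance. The lengthening in compound 4 is far greater than the single methyl of that modest step, and its direction points downward. Compound 4 is therefore expected to move by a number 19 percentage points lower from compound 3 to compound 4 (beyond the scatter) in this assay. The estimate for compound 4 in this assay is 58%, with a range from 30% to 82%.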

Compound 4, a percentage reported as inhibition, at one concentration (the size of the read-out at that concentration, not a potency): 10%
The estimate for compound 4 lay 48 percentage points above the measured number; measured number outside the range, below it.
By their numbers in this assay, from the lowest: compound 4; then compound 2; then compound 3; then compound 1.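

At this position on the chain beyond the carbonyl, heptyl in place of hydrogen gives a number 67 percentage points lower from compound 3 to compound 4 (beyond the scatter) in this assay and the corresponding octyl change gives a number 82 percentage points lower from compound 1 to compound 4 (beyond the scatter) so a long extension costs far more than the single methyl of the earlier modest step suggested. An acyl group therefore does not raise the number whatever its length: compound 4 has the lowest of the four numbers, and even compound 2, with hydrogen in place of the acyl group, gives 29% in this comparison. No measurement shown here explains this fall.

The compounds shown leave open whether the number declines gradually or abruptly between the propanoyl of compound 3 and the long chain of compound 4, since no butanoyl or hexanoyl lies between them. They also leave open how this position responds when the chain ends in a carboxylic acid or an amine, or when a phenyl ring replaces heptyl.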